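The source may report more compounds than this note shows. Statements on the series, on what has been measured and on what is new or still open speak of the compounds shown alone.

Values in a functional assay on RAW264.7 cells (Mus musculus) for inhibition, read by Griess assay, with stated times of 3 h and 24 h; on this read-out higher numbers stand for weaker inhibition and lower numbers for stronger inhibition:
compound 1 `C=C1CC[C@H]2[C@@](C)(CCC(=O)N[C@@]2(C)COC(=O)c2ccccc2)[C@@H]1/C=C/C1=CCOC1=O`: > 50000 nM (a limit)
compound 2 `C=C1CC[C@H]2[C@@](C)(CCC(=O)N[C@@]2(C)COC(=O)[C@@H]2CCCN2)[C@@H]1/C=C/C1=CCOC1=O`: > 50000 nM (a limit)
compound 3 `C=C1CC[C@H]2[C@@](C)(CC[C@@H](OC(=O)c3ccccc3)[C@@]2(C)NC=O)[C@@H]1/C=C/C1=CCOC1=O`: 50000 nM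

For the measured compounds named here, compound 3 gives 50000 nM, the only number in the set. Compound 1 and compound 2 are limits, with the limit of > 50000 nM in this assay, at which 2 of the 3 values shown sit.

Compound 4 `C=C1CC[C@H]2[C@@](C)(CC[C@@H](OC(=O)CN)[C@@]2(C)NC=O)[C@@H]1/C=C/C1=CCOC1=O` departs from compound 3 by one change: aminomethyl in place of phenyl on a carbonyl carbon. In words, this is aminomethyl in place of phenyl on a carbonyl carbon. The nearest measured change is a step that the two limits leave unreadable from compound 1 to compound 2, with pyrrolidin-2-yl in place of phenyl on a carbonyl carbon. Going by the values given here, that comparison gives no size to carry over and no direction, and no other measured step bears on this change. With nothing pointing either way, no shift beyond the scatter is expected in this assay, and the expected change is no change at the digits printed from compound 3 to compound 4 (within the scatter). For compound 4 the estimated value is 50000 nM, with an expected range of 20000 nM to 100000 nM.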

Compound 4, half-maximal inhibitory concentration: > 50000 nM
Compound 4: no number, only a limit; the forecaster's own chance of this, stated with the estimate: 60%; the middle value sits exactly at the limit.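

In this assay, the change from benzoyloxy to ((aminomethyl)carbonyl)oxy gives a number no lower from compound 3 to compound 4 (the limit leaves the size open), so this swap of phenyl for aminomethyl on the carbonyl carbon brings no stronger inhibition. Compound 4 gives > 50000 nM, which is a limit of the assay, so its size relative to compound 3 cannot be read, and the same holds for the pyrrolidin-2-yl step in the other pair. With this result, the series gathers further at a single limit: the limit of > 50000 nM in this assay, at which 3 of the 4 values shown sit.

Still open, as far as these compounds go, is whether any group on this carbonyl carbon can give a readable number stronger than the 50000 nM of compound 3. A longer alkyl chain, a carboxylic acid or a pyridine ring in place of aminomethyl would test this, but the compounds shown say nothing about them.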